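Branched ester on a dihydropyridine calcium-channel blocker

A few compounds are considered here, and "the series" means these few. Any claim that something is new, unique, unknown or untested is made for them only; others in the source may bear on it.

Measured compounds:
compound 1 `CCOC(=O)C1=C(C)NC(C)=C(C(=O)OC)C1c1csc(-c2ccc(Cl)cc2)n1` gives 22000 nM;
compound 2 `CCCOC(=O)C1=C(C)NC(C)=C(C(=O)OCC)C1c1csc(-c2ccc(Cl)cc2)n1` gives 4090 nM;
compound 3 `CCOC(=O)C1=C(C)NC(C)=C(C(=O)OCC(C)C)C1c1csc(-c2ccc(Cl)cc2)n1` gives 15400 nM.

All three were tested in an assay on isolated protein for antagonist activity at Voltage-dependent L-type calcium channel subunit alpha-1C (Cavia porcellus), with a stated time of 15 min; on this read-out lower numbers stand for stronger inhibition and higher numbers for weaker inhibition. Compound 1 has the highest number of the three; compound 3 stands closest to it, and compound 2 is furthest away. The unmeasured compound 4 `COC(=O)C1=C(C)NC(C)=C(C(=O)OC(C)(C)C)C1c1csc(-c2ccc(Cl)cc2)n1` is reached from compound 1 by a single change: tert-butyl in place of ethyl on an oxygen next to a carbonyl group.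

For the measured compounds named here, two measured steps bear on this. Lengthening an ester chain at an oxygen next to a carbonyl group gave a 5.4-fold lower number from compound 1 to compound 2 (0.73 log units; beyond the scatter), while adding an isopropyl at the same kind of position gave a 1.4-fold lower number from compound 1 to compound 3 (0.15 log units; within the scatter). The step of a 3.8-fold higher number from compound 2 to compound 3 (0.58 log units; beyond the scatter) shows that branching did not bring the number down as far as the straight chain did. The expectation for compound 4 is therefore a modestly lower number than for compound 1, though a step within the scatter cannot be ruled out. The estimated step is a 2.4-fold lower number from compound 1 to compound 4 (0.39 log units; beyond the scatter). Compound 4 is expected to give about 9000 nM, with a range from 3500 nM to 22000 nM.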

Compound 4, half-maximal inhibitory concentration: 46000 nM
Beside the measured number, compound 4's estimate is 5.1-fold (0.71 log units) below it; the measured number lies above the stated range.
By their numbers in this assay, from the lowest: compound 2; then compounds 3 and 1 (each within the scatter of the next); then compound 4.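

Replacing ethyl with tert-butyl on the ester oxygen gives a 2.1-fold higher number from compound 1 to compound 4 (0.32 log units; beyond the scatter) in this assay. This is the only step from compound 1 shown here that raises the number beyond the scatter, so weaker inhibition is now seen at this kind of position, not only stronger or unchanged inhibition. Adding carbon to an ester group therefore does not by itself lower the number: compound 2 goes one way, compound 4 goes the other, and compound 3 stays within the scatter of compound 1, while nothing measured here accounts for this difference in direction.

The compounds shown leave open whether an isopropyl placed directly on the ester oxygen would give a number closer to that of compound 1 or that of compound 4, and so how much branching this position accepts before the number rises. They also leave open how a longer straight chain, such as butyl, or an ester chain ending in an amine would compare with the ethyl of compound 1.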